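Formyl Replaces Amine on a Para-Substituted Ring

A few compounds are considered here, and "the series" means these few. Any claim that something is new, unique, unknown or untested is made for them only; others in the source may bear on it.

Compound 1, `CCCNCc1ccccc1OCCCCCC(=O)OCC`, in an ADME assay on Raji cells (Homo sapiens) for cytotoxicity, read by CellTiter-Glo and resazurin assay, with a stated time of 72 h (on this read-out higher numbers stand for an effect only at larger amounts of compound and lower numbers for an effect already at smaller amounts), gives > 26000 nM, a limit of the assay and not a number.
Compound 2, `CCCNCc1ccc(OCCCCCC(=O)OCC)cc1`, in this assay gives > 26000 nM, again a limit and not a number.
Compound 3, `CCOC(=O)CCCCCOc1ccccc1C=O`, in this assay gives > 26000 nM, likewise a limit and not a number.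

The difference between the cores of compound 1 and compound 2 is not broken down here. Compound 3 arises from compound 1 by formyl in place of (propylamino)methyl on an aromatic carbon. The step that the two limits leave unreadable from compound 1 to compound 3 cannot be read, since both ends sit at the limit of > 26000 nM in this assay, at which 3 of the 3 values shown sit. Compound 4, `CCOC(=O)CCCCCOc1ccc(C=O)cc1`, is not yet measured; it arises from compound 2 by formyl in place of (propylamino)methyl on an aromatic carbon, the same kind of change, the place now being para rather than ortho to a large group. In this assay the step from compound 2 to compound 4 is expected to be a number no higher from compound 2 to compound 4 (the limit leaves the size open), resting on compound 2 at > 26000 nM and on compound 3 at > 26000 nM. Compound 4 is estimated at 26000 nM, most likely again reported only as a limit.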

Compound 4, half-maximal effective concentration: > 26000 nM
Compound 4 was reported as a limit; the forecaster's own chance of this, stated with the estimate: 85%; the middle value lies on the limit itself.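

Compound 2 and compound 4 both give a limit of the assay and not a number, so no step between them can be read: the limit of > 26000 nM in this assay, at which 4 of the 4 values shown sit.

As far as these compounds go, whether formyl in place of (propylamino)methyl changes the effect on these cells at all remains open.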